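The compounds below may be only part of what the source reports. "The series", "measured", "known", "first", "only" and "open" are said of these compounds alone.

Compound 2 `CCCNc1nc(NCc2ccc(NC(=O)c3ccc(F)cc3)cc2)c2ccccc2n1` is one of two compounds tested in a functional assay on SW480 cells (Homo sapiens) for inhibition, read by luminescence and resazurin assay, with a stated time of 3 days (on this read-out lower numbers stand for stronger inhibition and higher numbers for weaker inhibition), where compound 2 gives 2000 nM. The other, compound 1 `O=S(=O)(Nc1ccc(CNc2nc(NC3CC3)nc3ccccc23)cc1)c1ccc(F)cc1`, gives in this assay 4100 nM, so compound 2 holds the lower, stronger number of the two. Compound 3 `CN1CCN(c2nc(NCc3ccc(NC(=O)c4ccc(F)cc4)cc3)c3ccccc3n2)CC1` is not yet measured; it differs from compound 2 by 4-methylpiperazin-1-yl in place of propylamino on an aromatic carbon. Going by these compounds, no such change has been measured here, so its size and direction stay open, and a modest shift either way, or none beyond the scatter, is plausible. Compound 3 is expected to give about 3000 nM in this assay, between 800 nM and 12000 nM, an expected step of a 1.5-fold higher number from compound 2 to compound 3 (0.18 log units; within the scatter).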

Compound 3, half-maximal inhibitory concentration: 2500 nM
The estimate for compound 3 lay 1.2-fold (0.08 log units) above the measured number; low and high end bracket the measured number.
By their numbers in this assay, from the lowest: compounds 2, 3 and 1 (each within the scatter of the next, the first and the last beyond it).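

Placing 4-methylpiperazin-1-yl instead of propylamino on the aromatic carbon between two ring nitrogen atoms gives a 1.3-fold higher number from compound 2 to compound 3 (0.10 log units; within the scatter) in this assay. This position therefore accepts a larger group with a six-membered non-aromatic ring and no hydrogen-bond donor, with no change beyond the scatter. Nothing available explains this result. Still open, going by these compounds, is whether a morpholine or a simple unsubstituted amine at this position would also stay within the scatter. A carboxylic acid on the same carbon is equally unresolved.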